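A few compounds are considered here, and "the series" means these few. Any claim that something is new, unique, unknown or untested is made for them only; others in the source may bear on it.

Compounds measured in a functional assay on SK-OV-3 cells (Homo sapiens) for inhibition, read by sulforhodamine B assay, with a stated time of 48 h; on this read-out higher numbers stand for weaker inhibition of growth and lower numbers for stronger inhibition of growth:
- compound 1 `O=C(Nc1cccc(-n2cc(-c3ccncc3)c(-c3ccc(Cl)c(O)c3)n2)c1)Nc1cccc(C(F)(F)F)c1`: 4970 nM
- compound 2 `COc1cc(-c2nn(-c3cccc(NC(=O)Nc4ccc(Cl)c(Cl)c4)c3)cc2-c2ccncc2)ccc1Cl`: 1930 nM
- compound 3 `COc1cc(-c2nn(-c3cccc(NC(=O)Nc4cccc(C(F)(F)F)c4)c3)cc2-c2ccncc2)ccc1Cl`: 2020 nM

Among these three numbers, compound 3 stands second highest. Its nearest neighbour is compound 2, which gives a step of a 1.0-fold higher number from compound 2 to compound 3 (0.02 log units; within the scatter) on exchange of the aryl group on the urea nitrogen, a difference inside the scatter. The furthest is compound 1, where the change is methyl in place of hydrogen on an oxygen on an aromatic ring. That step is a 2.5-fold lower number from compound 1 to compound 3 (0.39 log units; beyond the scatter) and is modest but beyond the scatter.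

Compound 4 `COc1cc(-c2nn(-c3cccc(NC(=O)c4ccccc4)c3)cc2-c2ccncc2)ccc1Cl` is not yet measured. It differs from compound 3 in one place: phenyl in place of (3-(trifluoromethyl)phenyl)amino on a carbonyl carbon. The urea of compound 3 thus becomes a benzamide, and the trifluoromethyl-bearing ring is gone. Among the compounds with values here, none of the measured steps touches this part of the molecule in the same way. The step from compound 2 to compound 3 shows only that swapping one substituted aryl for another on the urea leaves the number unchanged; it says nothing about removing the second nitrogen with its hydrogen-bond donor. For this assay the expectation is therefore uncertain; a step of a 2.0-fold higher number from compound 3 to compound 4 (0.30 log units; within the scatter) toward weaker growth inhibition is expected, with a wide range. Compound 4 is estimated at 4000 nM, between 1500 nM and 12000 nM.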

Compound 4, concentration for 50% growth inhibition: 1070 nM
The estimate for compound 4 lay 3.7-fold (0.57 log units) above the measured number; the measured number lies below the stated range.
By their numbers in this assay, from the lowest: compounds 4, 2 and 3 (each within the scatter of the next); then compound 1.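

In this assay the change from a urea to a benzamide gives a 1.9-fold lower number from compound 3 to compound 4 (0.28 log units; within the scatter) and, from the other urea, a 1.8-fold lower number from compound 2 to compound 4 (0.26 log units; within the scatter), both with phenyl taking the place of the whole substituted arylamino group on the carbonyl carbon. The earlier compounds had shown only that one substituted aryl on the urea nitrogen could replace another, whereas these steps show that, across compound 2, compound 3 and compound 4, the amide-type nitrogen with its hydrogen-bond donor and the ring substituents, trifluoromethyl in one case and the two chlorines in the other, can all be absent without the number moving beyond the scatter. No evidence at hand accounts for this result.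

Because each step removes the nitrogen and the ring substituents together, the compounds shown leave open what either change does alone, which a benzamide carrying trifluoromethyl on its phenyl ring would separate. Also open, on these data alone, is whether the step from compound 1 to compound 3 holds in the benzamide series, and how an amine, a carboxylic acid or a longer chain in place of the phenyl on the carbonyl carbon would read.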